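Working notes: dimethylamino in place of phenoxy

The compounds below may be only part of what the source reports. "The series", "measured", "known", "first", "only" and "open" are said of these compounds alone.

Two members of the series have numbers in a functional assay on TK-10 cells (Homo sapiens) for cytotoxicity, read by sulforhodamine B assay, with a stated time of 48 h, tested at 0.01 uM; on this read-out higher numbers stand for a weaker effect at the one concentration tested and lower numbers for a stronger effect. Compound 1 `COc1cc(C)cc(-c2nn(CC#N)cc2-c2ccc(-c3cccc(C(C)=O)c3)nc2)c1` gives 100%. Compound 2 `Cc1cc(O)cc(-c2nn(CC#N)cc2-c2ccnc(-c3ccc(Oc4ccccc4)cc3)c2)c1` gives 99%. Compound 2 carries the smaller of the two numbers, but its gap to compound 1 lies within the scatter, so the two stand together at the level of no measurable effect at this concentration. Within the data shown here, no pair of measured compounds differs in a single place, so no step size is known from the series itself.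

Compound 3 `Cc1cc(O)cc(-c2nn(CC#N)cc2-c2ccnc(-c3ccc(N(C)C)cc3)c2)c1` differs from compound 2 in one place: dimethylamino in place of phenoxy on an aromatic carbon. Both measured numbers sit at the top of the scale, and nothing in the series shows a change of this kind moving the read-out. For compound 3 in this assay the expected step is no change at the digits printed from compound 2 to compound 3 (within the scatter), none beyond the scatter. Compound 3 is therefore estimated at 99%, with a range from 89% to 107%.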

Compound 3, a percentage reported as activity, at one concentration (the size of the read-out at that concentration, not a potency): 107%
For compound 3 the middle estimate is 8 percentage points below the measured one; measured number inside the range.
By their numbers in this assay, from the lowest: compounds 2, 1 and 3 (each within the scatter of the next).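

In this assay, the series now has its first measured single-place change: dimethylamino in place of phenoxy on an aromatic carbon, para to a large group, gives a number 8 percentage points higher from compound 2 to compound 3 (within the scatter). At this position, a group with no ring and 3 heavy atoms thus stands in for one with a six-membered aromatic ring and 7 heavy atoms, and the read-out stays at the level of no measurable effect at the one concentration tested. No measurement at hand bears on the reason for this result.

The compounds shown leave open whether a different group at this place, such as a carboxylic acid or a longer chain ending in an amine, would move the read-out beyond the scatter. They also leave open whether phenoxy and dimethylamino would separate at a higher concentration.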